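A Halogenated Aryl Replaces Nitrophenyl on the Hydrazone

The compounds below may be only part of what the source reports. "The series", "measured", "known", "first", "only" and "open" are said of these compounds alone.

Three hydrazone compounds built on one shared core have been tested in a functional assay on A549 cells (Homo sapiens) for cytotoxicity, read by MTT assay, with a stated time of 72 h; on this read-out higher numbers stand for weaker inhibition and lower numbers for stronger inhibition. Compound 2 `O=C(N/N=C/c1cccc([N+](=O)[O-])c1)N1CCc2ncnc(Nc3ccc(F)c(Cl)c3)c2C1` gives 43100 nM in this assay, the highest of the three numbers; compound 1 `O=C(N/N=C/c1ccccc1)N1CCc2ncnc(Nc3ccc(F)c(Cl)c3)c2C1` gives 31500 nM and compound 3 `Cc1ccc(/C=N/NC(=O)N2CCc3ncnc(Nc4ccc(F)c(Cl)c4)c3C2)cc1C` gives 15600 nM. The step of a 1.4-fold higher number from compound 1 to compound 2 (0.14 log units; within the scatter) lies within the scatter, whereas a 2.0-fold lower number from compound 1 to compound 3 (0.31 log units; beyond the scatter) and a 2.8-fold lower number from compound 2 to compound 3 (0.44 log units; beyond the scatter) are modest steps beyond it. Compound 4 `O=C(N/N=C/c1cc(F)c(F)cc1Cl)N1CCc2ncnc(Nc3ccc(F)c(Cl)c3)c2C1` has not yet been measured; it differs from compound 2 in one place: 2-chloro-4,5-difluorophenyl in place of 3-nitrophenyl on a carbon with a double bond to nitrogen. For the measured compounds named here, no measured step involves a halogenated ring on the carbon with a double bond to nitrogen, so the two steps that bear on this change show only that the number fell when the 3-nitrophenyl of compound 2 gave way to another aryl ring, as in a 2.8-fold lower number from compound 2 to compound 3 (0.44 log units; beyond the scatter). For compound 4 the expected step is a 1.7-fold lower number from compound 2 to compound 4 (0.24 log units; within the scatter), with the direction far from certain. The estimate for compound 4 is 25000 nM, within a range from 8000 nM to 70000 nM.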

Compound 4, half-maximal inhibitory concentration: 7550 nM
Beside the measured number, compound 4's estimate is 3.3-fold (0.52 log units) above it; the measured number lies below the stated range.
By their numbers in this assay, from the lowest: compound 4; then compound 3; then compounds 1 and 2 (each within the scatter of the next).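

With the first halogenated ring at the carbon with a double bond to nitrogen, the number fell further than with any earlier aryl ring: a 5.7-fold lower number from compound 2 to compound 4 (0.76 log units; beyond the scatter), a 4.2-fold lower number from compound 1 to compound 4 (0.62 log units; beyond the scatter) and a 2.1-fold lower number from compound 3 to compound 4 (0.32 log units; beyond the scatter). The position therefore tolerates a ring carrying chlorine and fluorine, and the change from 3-nitrophenyl keeps the count of heavy atoms while removing that group's hydrogen-bond acceptors. No measurement shown here accounts for the fall in the number.

The compounds shown do not separate the contribution of the chlorine from that of the two fluorines, as all three halogens arrive together in compound 4. Also open, on these data alone, is how the number would respond to an amine or a carboxylic acid on this ring, or to a saturated ring in its place.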